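The source may report more compounds than this note shows. Statements on the series, on what has been measured and on what is new or still open speak of the compounds shown alone.

Working notes on the series. Compound 1 `O=C(Nc1ccc(Nc2ncnc3c2OCCN3)cc1)Nc1ccc(C(F)(F)F)cc1` gives 306 nM in an assay on isolated protein for inhibition of proto-oncogene tyrosine-protein kinase receptor Ret (Homo sapiens), read by 33P incorporation, with stated times of 15 min and 40 min; on this read-out higher numbers stand for weaker inhibition and lower numbers for stronger inhibition. Compound 2 `O=C(Nc1ccc(Nc2ncnc3c2OCCN3)cc1)Nc1cc(Cl)cc(Cl)c1` gives 865 nM; the step of a 2.8-fold higher number from compound 1 to compound 2 (0.45 log units; beyond the scatter). Compound 3 `CC(C)(C)c1cc(NC(=O)Nc2ccc(Nc3ncnc4c3OCCN4)cc2)no1` gives 10 nM, the lowest of the three numbers, with a 31-fold lower number from compound 1 to compound 3 (1.49 log units; beyond the scatter) and an 87-fold lower number from compound 2 to compound 3 (1.94 log units; beyond the scatter); on these numbers compound 3 is the most potent measured member.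

Compound 4 `CC(C)(C)c1csc(NC(=O)Nc2ccc(Nc3ncnc4c3OCCN4)cc2)n1` differs from compound 3 in one place: 4-(tert-butyl)-1,3-thiazol-2-yl in place of 5-(tert-butyl)-1,2-oxazol-3-yl on an amide-type nitrogen. Both measured steps that reach compound 3 replace a substituted phenyl with a tert-butyl five-membered heteroaryl, and both are large. Within the data shown here, no measured step compares two such five-membered rings with each other, so nothing in the data shows how the swap of ring type and hetero atoms will read; the group entering is again a tert-butyl five-membered aromatic ring with two hetero atoms. The expectation is therefore a step of a 1.5-fold higher number from compound 3 to compound 4 (0.18 log units; within the scatter) in this assay, not beyond the scatter, with compound 4 estimated at 15 nM and a range from 5 nM to 45 nM.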

Compound 4, half-maximal inhibitory concentration: 3150 nM
Estimate against measurement, compound 4: 210-fold (2.32 log units) below; the whole stated range lies below it.
By their numbers in this assay, from the lowest: compound 3; then compound 1; then compound 2; then compound 4.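

The two tert-butyl five-membered rings match in every count, yet they are far from interchangeable on this amide-type nitrogen in this assay: a 320-fold higher number from compound 3 to compound 4 (2.50 log units; beyond the scatter). The 4-(tert-butyl)-1,3-thiazol-2-yl group also reads weaker than both substituted phenyl groups, with a 3.6-fold higher number from compound 2 to compound 4 (0.56 log units; beyond the scatter) and a 10-fold higher number from compound 1 to compound 4 (1.01 log units; beyond the scatter), so among these compounds a tert-butyl five-membered aromatic ring does not by itself give a low number. No measurement on hand bears on the cause of this gap.

The two rings differ both in hetero atoms and in where the tert-butyl sits, and the compounds shown do not separate these two changes. Also open, from the compounds shown here alone, is how the 5-(tert-butyl)-1,2-oxazol-3-yl group reads with isopropyl or cyclopropyl in place of its tert-butyl.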